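Moving One Methyl Group Around a Phenyl Ring

This account rests on a few compounds, and the source may have more. Where it says the series, first, only, none or still open, it means among the compounds named here.

In a functional assay on K562 cells (Homo sapiens) for cytotoxicity, read by ELISA, with a stated time of 4 days (a lower number here means a stronger inhibitor, a higher number a weaker inhibitor), three compounds built on a shared core have been measured. Compound 1 `Clc1ccc(-c2cc(-c3ccoc3)cc(-c3ccco3)n2)s1` gives 16200 nM, compound 2 `Cc1ccc(-c2cc(-c3ccoc3)cc(-c3ccc(Cl)s3)n2)o1` gives 12700 nM, and compound 3 `Cc1ccccc1-c1cc(-c2ccoc2)cc(-c2ccc(Cl)s2)n1` gives 12300 nM. These numbers lie within the usual scatter of repeated measurements, so compound 3 stands level with the other two. The closest pair shows a 1.0-fold lower number from compound 2 to compound 3 (0.01 log units; within the scatter). The other two steps are a 1.3-fold lower number from compound 1 to compound 3 (0.12 log units; within the scatter), where 2-methylphenyl replaces furan-2-yl, and a 1.3-fold lower number from compound 1 to compound 2 (0.11 log units; within the scatter), where methyl replaces hydrogen.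

Compound 4 `Cc1cccc(-c2cc(-c3ccoc3)cc(-c3ccc(Cl)s3)n2)c1` is still unmeasured. It has the same atoms as compound 3, joined differently, with 3-methylphenyl in place of 2-methylphenyl next to the ring nitrogen: 3-methylphenyl in place of 2-methylphenyl on an aromatic carbon. Among the compounds with values here, no measured step shows this exact change. The nearest evidence is the two changes of group at this same place, a 1.3-fold lower number from compound 1 to compound 3 (0.12 log units; within the scatter) and a 1.0-fold lower number from compound 2 to compound 3 (0.01 log units; within the scatter), and neither leaves the scatter. No step beyond the scatter is therefore expected in this assay, in either direction. The estimate amounts to an expected 1.1-fold higher number from compound 3 to compound 4 (0.02 log units; within the scatter). Compound 4 is expected to give about 13000 nM, within an estimated range of 7000 nM to 24000 nM.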

Compound 4, half-maximal inhibitory concentration: 13700 nM
Estimate against measurement, compound 4: 1.1-fold (0.02 log units) below; low and high end bracket the measured number.
By their numbers in this assay, from the lowest: compounds 3, 2, 4 and 1 (each within the scatter of the next).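

Moving the methyl group on the phenyl ring next to the ring nitrogen, with 3-methylphenyl in place of 2-methylphenyl, gives a 1.1-fold higher number from compound 3 to compound 4 (0.05 log units; within the scatter) in this assay, so this shift of one methyl group leaves the number within the scatter. The new compound also stays level with the two furan-bearing compounds at this place, with a 1.1-fold higher number from compound 2 to compound 4 (0.03 log units; within the scatter) where 5-methylfuran-2-yl leaves and a 1.2-fold lower number from compound 1 to compound 4 (0.07 log units; within the scatter) where furan-2-yl leaves, so all four groups compared at this position remain indistinguishable in this cell assay. The data offer no explanation for this flat result.

From the compounds shown here alone, all four compounds keep the furan-3-yl and 5-chlorothiophen-2-yl groups, so what changes at those places remains open. Also open, going by these compounds, is whether an amine or a carboxylic acid on the phenyl ring, or a longer chain in place of the methyl, would move the number beyond the scatter.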